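A few compounds are considered here, and "the series" means these few. Any claim that something is new, unique, unknown or untested is made for them only; others in the source may bear on it.

In a functional assay on NCI-H1975 cells (Homo sapiens) for cytotoxicity, read by CCK-8 assay, with a stated time of 72 h (a lower number here means a stronger inhibitor, a higher number a weaker inhibitor), the measured compounds stand as follows:

compound 1 `C=CCn1c(=O)/c(=C\c2cccc(Cl)c2)[nH]c(=O)/c1=C\c1ccccc1OC` gives 5100 nM
compound 2 `C=CCn1c(=O)/c(=C\c2cccc(Cl)c2Cl)[nH]c(=O)/c1=C\c1ccccc1OC` gives 4500 nM
compound 3 `COc1ccccc1/C=c1\c(=O)[nH]/c(=C/c2cccc(Cl)c2Cl)c(=O)n1C` gives 300 nM

Compound 3 holds the lowest number of the three, and its steps to both others lie beyond the scatter. Compound 2 and compound 3 differ in the chain on the ring nitrogen, (hydrogen in place of vinyl on a saturated chain carbon bound to an aromatic nitrogen), and this step, a 15-fold lower number from compound 2 to compound 3 (1.18 log units; beyond the scatter), is the large one in the set. Within the allyl series the removal of one chloro, (hydrogen in place of chloro on an aromatic carbon), gives a 1.1-fold higher number from compound 2 to compound 1 (0.05 log units; within the scatter), a step that does not leave the scatter.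

Compound 4 `COc1ccccc1/C=c1\c(=O)[nH]/c(=C/c2ccccc2Cl)c(=O)n1C` is not yet measured in this assay. It is made from compound 3 by the same kind of change, (hydrogen in place of chloro on an aromatic carbon); the difference is in the place, which here is meta to the large group rather than ortho to it. Beyond this one step there is nothing in the set on the effect of the placement of the chloro groups. The expectation for compound 4 therefore rests on compound 2 and compound 1, whose step a 1.1-fold higher number from compound 2 to compound 1 (0.05 log units; within the scatter) stayed within the scatter, and the estimated step of a 1.2-fold higher number from compound 3 to compound 4 (0.07 log units; within the scatter) is taken of similar size. Within the data shown here, on that basis compound 4 is expected to give 350 nM, with the range 150 nM to 900 nM reflecting that the shared core of compound 3 has been tested with only one aryl group.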

Compound 4, half-maximal inhibitory concentration: 200 nM
The estimate for compound 4 lay 1.8-fold (0.24 log units) above the measured number, within the range that was stated.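

In this assay, the change from 2,3-dichlorophenyl to 2-chlorophenyl gives a 1.5-fold lower number from compound 3 to compound 4 (0.18 log units; within the scatter), so on this core too, taking off one chloro leaves a step that does not pass the scatter. Set beside the earlier step on the allyl core, the same kind of change reads alike on both cores: the same change on two cores in this assay, a 1.1-fold higher number (0.05 log units; within the scatter) from compound 2 to compound 1 and a 1.5-fold lower number (0.18 log units; within the scatter) from compound 3 to compound 4, 1.7-fold (0.23 log units) apart, within the scatter of two such steps. This supports carrying the loss of one chloro across these two cores as a step within the scatter, but it does not show that the result holds on other cores, and it does not separate core from place, since the structures show that the chloro leaves a different place in each pair.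

Among these compounds, still open is how far the chain on the ring nitrogen can move from allyl and methyl, for example to ethyl, to a longer chain or to a chain ending in an amine, given that this chain carries the one large step. Also open, from the compounds shown here alone, are an unsubstituted phenyl in place of the chlorinated aryl group, fluoro or methoxy in place of chloro, and a hydroxyl or a carboxylic acid in place of the methoxy on the other aryl group.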